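Hydroxy to Fluoro: Expecting Recovery of Growth Inhibition

The source may report more compounds than this note shows. Statements on the series, on what has been measured and on what is new or still open speak of the compounds shown alone.

Compound 1 `CSc1ccc(C2=C(c3ccc(F)c(F)c3)C(=O)N3CCCC3C2)cc1`: 100 nM
Compound 2 `CSc1ccc(C2=C(c3ccc(O)cc3)C(=O)N3CCCC3C2)cc1`: > 100000 nM

In a functional assay on A498 cells (Homo sapiens) for cytotoxicity (a higher number here means a weaker inhibitor of growth, a lower number a stronger inhibitor of growth), compound 1 gives 100 nM. Compound 2 gives only a limit of the assay, > 100000 nM, so no number is known for it. That leaves compound 2 at the limit of > 100000 nM in this assay, at which 1 of the 2 values shown sits. Among the measured compounds shown here, the one measured step is an at least 1000-fold higher number from compound 1 to compound 2 (3.00 log units; beyond the scatter), where a 4-hydroxyphenyl replaced a 3,4-difluorophenyl on a double-bonded ring carbon.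

Compound 3 `CSc1ccc(C2=C(c3ccc(F)cc3)C(=O)N3CCCC3C2)cc1` differs from compound 2 by fluoro in place of hydroxy on an aromatic carbon. This reverses the hydroxy-for-fluorine part of that measured step, leaving one fluorine fewer than in compound 1. Because compound 1 gives 100 nM and the step to compound 2 was an at least 1000-fold higher number from compound 1 to compound 2 (3.00 log units; beyond the scatter), most of the loss is expected to be regained. The expected step is an at least 400-fold lower number from compound 2 to compound 3 (2.60 log units; beyond the scatter). Compound 3 is therefore estimated at 250 nM, within a range from 50 nM to 2000 nM.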

Compound 3, concentration for 50% growth inhibition: 100 nM
For compound 3 the middle estimate is 2.5-fold (0.40 log units) above the measured one; low and high end bracket the measured number.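

In this assay, the change from hydroxy to fluoro on this ring alone gives an at least 1000-fold lower number from compound 2 to compound 3 (3.00 log units; beyond the scatter), so the large step seen earlier can now be tied to this one exchange at this place on the ring. The extra fluorine of compound 1 adds nothing that can be seen here, since removing it gives no change at the digits printed from compound 1 to compound 3 (within the scatter). Compound 2 gives only a limit, not a number, so its steps are minimum sizes: the limit of > 100000 nM in this assay, at which 1 of the 3 values shown sits.

Going by these compounds, it remains open whether fluoro itself is needed at this place, or whether plain hydrogen, a chloro or a methoxy would serve as well. Equally open, on these data alone, is whether an amine here would behave like the hydroxy of compound 2 or like the fluoro of compound 3.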